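The compounds below may be only part of what the source reports. "The series", "measured", "known", "first", "only" and "open" are said of these compounds alone.

Values measured in a functional assay on A549 cells (Homo sapiens) for antiproliferative activity, read by CCK-8 assay, with a stated time of 72 h (on this read-out higher numbers stand for weaker inhibition of growth and lower numbers for stronger inhibition of growth), for the three compounds tested so far:

Compound 1 `CCC1C(=O)N(C)c2cnc(Nc3ccc(S(=O)(=O)NC)cc3)nc2N1c1ccn(C)n1` gives 12600 nM
Compound 2 `CCC1C(=O)N(C)c2cnc(-n3ccc4cc(C(=O)NC)ccc43)nc2N1c1ccn(C)n1` gives 43100 nM
Compound 3 `CC[C@@H]1C(=O)N(C)c2cnc(Nc3ccc(S(N)(=O)=O)cc3)nc2N1C1CCCC1` gives 3390 nM

Of these three, compound 2 has the highest number and so shows the weakest inhibition of growth. Its gaps to compound 1 and to compound 3 both lie beyond the scatter, and the gap to compound 3 is the wider of the two. Compound 1 and compound 3 differ from compound 2 in more than one place, so neither gap isolates a single structural change.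

Compound 4 `CCCCNC(=O)c1ccc2c(ccn2-c2ncc3c(n2)N(c2ccn(C)n2)C(CC)C(=O)N3C)c1` has not yet been measured. It differs from compound 2 by propyl in place of hydrogen on a saturated chain carbon bound to an amide-type nitrogen which turns methylcarbamoyl into butylcarbamoyl. Going by the values given here, no measured pair shows what this change does. In this assay a modest step toward a lower number is expected, near the edge of the scatter or slightly beyond it. Compound 2 at 43100 nM sits at the top of the measured span, so the estimate leans downward, though with little support. The expected change is a 1.7-fold lower number from compound 2 to compound 4 (0.24 log units; within the scatter) and it remains an estimate. For compound 4 the estimated value is 25000 nM with an expected range from 8000 nM to 80000 nM as its span.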

Compound 4, concentration for 50% growth inhibition: 37300 nM
The estimate for compound 4 lay 1.5-fold (0.17 log units) below the measured number, within the range that was stated.
By their numbers in this assay, from the lowest: compound 3; then compound 1; then compounds 4 and 2 (each within the scatter of the next).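

In this assay, going by these compounds alone, the exchange of methylcarbamoyl for butylcarbamoyl, with propyl in place of hydrogen on a saturated chain carbon bound to an amide-type nitrogen, gives the first reading of a single change in this set: a 1.2-fold lower number from compound 2 to compound 4 (0.06 log units; within the scatter) and this is the only step that can be read here. On this one pair, lengthening the chain from methyl to butyl at this place does not move the number beyond the usual scatter, so the butyl chain is tolerated without a measurable gain or loss in inhibition of growth. Nothing measured here bears on why this step is so small.

From the compounds shown here alone, what remains open is whether a group other than a plain alkyl chain at this place, such as a terminal amine, a carboxylic acid or a hydroxyl on the butyl chain, or a chain longer than butyl, would move the number beyond the scatter. Also open, going by these compounds, is whether the same change would read the same way on compounds that carry other groups on the shared core, as the present reading rests on a single pair in one assay.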